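Trichloro versus dichloro aryl on two peroxide cores

The compounds below may be only part of what the source reports. "The series", "measured", "known", "first", "only" and "open" are said of these compounds alone.

Compound 1 `C=C(c1ccc(Cl)c(Cl)c1Cl)C1COC2(CCCC2)OO1` and compound 2 `C=C(c1ccc(Cl)c(Cl)c1)C1COC2(CCCC2)OO1` share one core, and in a functional assay on HepG2 cells (Homo sapiens) for inhibition, read by MTT assay, with a stated time of 72 h (a lower number here means a stronger inhibitor, a higher number a weaker inhibitor), compound 1 gives 8450 nM while compound 2 gives 62600 nM. Their difference is hydrogen in place of chloro on an aromatic carbon and it made a 7.4-fold higher number from compound 1 to compound 2 (0.87 log units; beyond the scatter). Compound 3 `C=C(c1ccc(Cl)c(Cl)c1Cl)C1COC2(CCCCC2)OO1` carries a second core; how the two cores differ is not broken down here. In this assay compound 3 gives 9020 nM. Compound 4 `C=C(c1ccc(Cl)cc1Cl)C1COC2(CCCCC2)OO1` differs from compound 3 by hydrogen in place of chloro on an aromatic carbon, the same kind of change, though here the place is ortho to two chloro groups and meta to a large group rather than ortho to one chloro group and to a large group. Compound 4 is expected to show a 5.0-fold higher number from compound 3 to compound 4 (0.70 log units; beyond the scatter), a step of similar size, because the earlier step was a 7.4-fold higher number from compound 1 to compound 2 (0.87 log units; beyond the scatter). Compound 4 is thus estimated at 45000 nM, between 12000 nM and 150000 nM.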

Compound 4, half-maximal inhibitory concentration: 17600 nM
The estimate for compound 4 lay 2.6-fold (0.41 log units) above the measured number; low and high end bracket the measured number.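

In this assay, the change from chloro to hydrogen did not carry over at the same size from one core to the other: the same change on two cores in this assay, a 7.4-fold higher number (0.87 log units; beyond the scatter) from compound 1 to compound 2 and a 2.0-fold higher number (0.29 log units; within the scatter) from compound 3 to compound 4, 3.8-fold (0.58 log units) apart, beyond the scatter of two such steps. On the second core the change gave a 2.0-fold higher number from compound 3 to compound 4 (0.29 log units; within the scatter), so there it cannot be told apart from the scatter of repeated measurements. This does not show that the core alone sets the gap: the chloro also leaves a different place in each pair, ortho to two chloro groups in compound 3 but ortho to one chloro group and to a large group in compound 1, and these pairs cannot separate the two.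

The compounds shown leave open how the change behaves at one fixed place on both cores. They also leave open whether a fluoro, methyl or methoxy group in that place would give numbers like those of chloro.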